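Aryl on the ring amide nitrogen of compound 2

This account rests on a few compounds, and the source may have more. Where it says the series, first, only, none or still open, it means among the compounds named here.

Of the compounds shown here, three of one core have numbers so far. Compound 1 `O=C1NNC(=O)C2(CSC3=C2C(=O)c2ncccc2C3=O)N1` gives 48 nM in a functional assay on CCRF-SB cells (Homo sapiens) for antiproliferative activity, read by MTT assay, with a stated time of 96 h; a higher number here means a weaker inhibitor, a lower number a stronger inhibitor. Compound 2 `O=C1NC(=O)C2(CSC3=C2C(=O)c2ncccc2C3=O)N1` gives 150 nM in this assay, and compound 3 `O=C1NN(c2ccccc2)C(=O)C2(CSC3=C2C(=O)c2ncccc2C3=O)N1` gives 39 nM. Compound 2 thus stands highest of the three numbers; the nearest is compound 1, lower by a gap beyond the scatter, and the furthest is compound 3, also beyond the scatter.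

The unmeasured compound 4 `O=C1C2=C(C(=O)c3ncccc31)C1(CS2)NC(=O)N(c2ccncc2)C1=O` differs from compound 2 in a single place: pyridin-4-yl in place of hydrogen on an amide-type nitrogen in a ring. For the measured compounds named here, the one measured step that bears on this change is the one in which phenyl replaced hydrogen on an amide-type nitrogen in a ring, a 1.2-fold lower number from compound 1 to compound 3 (0.09 log units; within the scatter), a step within the scatter. Two caveats apply: compound 4 carries pyridin-4-yl rather than phenyl, and the ring bearing the nitrogen differs between compound 1 and compound 2, so the comparison is only a partial guide.

On this basis no step beyond the scatter is expected, in either direction, since the analogous step from compound 1 to compound 3 was a 1.2-fold lower number from compound 1 to compound 3 (0.09 log units; within the scatter). Compound 4 is therefore estimated at 130 nM, within 55 nM to 320 nM. The expected step is a 1.2-fold lower number from compound 2 to compound 4 (0.06 log units; within the scatter).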

Compound 4, half-maximal inhibitory concentration: 1 nM
The estimate for compound 4 lay 130-fold (2.11 log units) above the measured number, outside the stated range (below it).
By their numbers in this assay, from the lowest: compound 4; then compounds 3 and 1 (each within the scatter of the next); then compound 2.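

In this assay the amide-type nitrogen in the five-membered non-aromatic ring proves to be a position of large effect, not a silent one: pyridin-4-yl in place of hydrogen gives a 150-fold lower number from compound 2 to compound 4 (2.18 log units; beyond the scatter) and so turns the weakest entry of the set into the strongest. The earlier change on such a nitrogen, phenyl in place of hydrogen, gave only a 1.2-fold lower number from compound 1 to compound 3 (0.09 log units; within the scatter) on the core of compound 1, so a step on one core does not carry over to a different group on another core. Nothing shown here accounts for the size of the new step.

Two variables changed between the earlier step and the new one, the group and the ring that carries it, and the compounds shown do not separate them: phenyl, pyridin-3-yl or pyridin-2-yl on the same nitrogen of compound 2 would show whether the step follows the aromatic ring as such or the placing of its nitrogen, and pyridin-4-yl on the core of compound 1 would test the role of the ring. Going by these compounds, whether a non-aromatic group such as methyl or a short chain ending in an amine keeps any of this gain also remains open.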